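Swapping a hydroxypiperidinyl end for a hydroxymethyl end

A few compounds are considered here, and "the series" means these few. Any claim that something is new, unique, unknown or untested is made for them only; others in the source may bear on it.

Compound 1 `Cn1ncc(Cl)c1-c1cc(C(=O)N[C@@H]2CN[C@H](CC(O)CO)C[C@H]2c2ccc(Cl)c(Cl)c2)oc1Cl` - 70 nM
Compound 2 `Cn1ncc(Cl)c1-c1cc(C(=O)N[C@@H]2CN[C@H](CCN3CCC(O)CC3)C[C@H]2c2ccc(Cl)c(Cl)c2)oc1Cl` - 1140 nM

In a functional assay on LNCaP cells (Homo sapiens) for antiproliferative activity (a higher number here means a weaker inhibitor, a lower number a stronger inhibitor), compound 2 has the higher of the two numbers, beyond the scatter from compound 1. Compound 3 `Cn1ncc(Cl)c1-c1cc(C(=O)N[C@@H]2CN[C@H](CCCO)C[C@H]2c2ccc(Cl)c(Cl)c2)oc1Cl` differs from compound 2 as follows (hydroxymethyl in place of 4-hydroxypiperidin-1-yl on a saturated chain carbon, two bonds along the chain from a saturated ring carbon), with hydroxymethyl in place of 4-hydroxypiperidin-1-yl on a saturated chain carbon, two bonds along the chain from a saturated ring carbon. Going by the values given here, one measured step bears on this, the large 16-fold higher number from compound 1 to compound 2 (1.21 log units; beyond the scatter), which brought in the same 4-hydroxypiperidin-1-yl group. A large step of similar size towards a lower number is therefore expected in this assay. The expected step is a 10-fold lower number from compound 2 to compound 3 (1.02 log units; beyond the scatter). Compound 3 is estimated at 110 nM (range 40 nM to 350 nM).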

Compound 3, half-maximal inhibitory concentration: 210 nM
Beside the measured number, compound 3's estimate is 1.9-fold (0.28 log units) below it; low and high end bracket the measured number.
By their numbers in this assay, from the lowest: compound 1; then compound 3; then compound 2.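

In this assay, hydroxymethyl in place of 4-hydroxypiperidin-1-yl on this chain gives a stronger inhibitor (a 5.4-fold lower number from compound 2 to compound 3 (0.73 log units; beyond the scatter)). The piperidine end is therefore costly on the 3-hydroxypropyl chain too, not only beside the diol of the earlier pair. Hydrogen in place of hydroxy on a saturated chain carbon bound to two saturated chain carbons gives a weaker inhibitor (a 3.0-fold higher number from compound 1 to compound 3 (0.48 log units; beyond the scatter)), so that second hydroxy also counts in this assay.

From the compounds shown here alone, whether a simple amine or a carboxylic acid at the chain end, or a longer chain ending in hydroxy, would keep the lower number remains open. No available evidence accounts for either step.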